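One Aromatic Ring for Another on a Shared Core

The source may hold more compounds than are shown below. What is called first, only, known or untested is meant among the compounds shown, and "the series" means these compounds.

The compounds here share one core and differ only in the aromatic ring attached to a saturated chain carbon bound to a nitrogen on an aromatic ring. All were tested in a functional assay on MCF cells (Homo sapiens) for antiproliferative activity, with a stated time of 72 h; on this read-out lower numbers stand for stronger inhibition and higher numbers for weaker inhibition. Compound 2, `OC[C@H]1O[C@@H](n2cnc3c(NCc4ccc(Cl)c(Cl)c4)ncnc32)[C@H](O)[C@@H]1O`, gives 88800 nM. That is the highest of the two numbers in hand; its nearest neighbour, compound 3, `COc1ccc(CNc2ncnc3c2ncn3C2OC(CO)[C@@H](O)[C@H]2O)c(O)c1`, gives 2200 nM, a gap well beyond the usual scatter. For compound 1, `OC[C@H]1O[C@@H](n2cnc3c(NCc4ccccc4Cl)ncnc32)[C@H](O)[C@@H]1O`, this assay reports only a limit, > 166000 nM, and not a number.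

Compound 4, `OC[C@H]1O[C@@H](n2cnc3c(NCc4ccc(C(F)(F)F)cc4)ncnc32)[C@H](O)[C@@H]1O`, differs from compound 2 in one place: 4-(trifluoromethyl)phenyl in place of 3,4-dichlorophenyl on a saturated chain carbon bound to a nitrogen on an aromatic ring. Within the data shown here, the single measured step that touches the same place is an at least 1.8-fold lower number from compound 1 to compound 2 (0.27 log units; that floor lies within the scatter). That step rests on (the limit of > 166000 nM in this assay, at which 1 of the 3 values shown sits), so its true size is known only as a floor, and that floor lies within the scatter. There is thus no measured evidence that changing the aromatic ring at this place moves the number beyond the scatter, and no step beyond the scatter is expected for compound 4, so the estimated step is a 1.0-fold higher number from compound 2 to compound 4 (0.01 log units; within the scatter). Compound 4 is therefore expected to give about 90000 nM, between 30000 nM and 250000 nM, with a real chance that this assay again reports only a limit.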

Compound 4, half-maximal inhibitory concentration: > 166000 nM
Compound 4: no number, only a limit (the forecaster's own chance of this, stated with the estimate: 30%); middle value at least 1.8-fold (0.26 log units) away from the limit.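

In this assay compound 4 gives > 166000 nM, which is a limit of the assay and not a number, so a ring carrying no chlorine at this place now joins the 2-chlorophenyl ring of compound 1 in reporting only a limit. Replacing 3,4-dichlorophenyl with 4-(trifluoromethyl)phenyl gives an at least 1.8-fold higher number from compound 2 to compound 4 (0.27 log units; that floor lies within the scatter), so this change has a floor but no measured size, and that floor does not show a real difference between the two rings. The step linking the two compounds that share the limit cannot be read, so the place can be compared only through compound 2: the limit of > 166000 nM in this assay, at which 2 of the 4 values shown sit.

As far as these compounds go, the true size of the step to compound 4 remains unknown, as does whether the 4-(trifluoromethyl)phenyl ring truly gives weaker inhibition than the 3,4-dichlorophenyl ring. Also open, from the compounds shown here alone, is whether a phenyl ring carrying an amine or a carboxylic acid on a saturated chain carbon bound to a nitrogen on an aromatic ring would give a measurable number in this assay.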